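The compounds below may be only part of what the source reports. "The series", "measured", "known", "first", "only" and "open" are said of these compounds alone.

Going by the values given here, compound 3 `Cc1ccccc1-c1cccc(COc2ccc([C@H](CC(=O)O)c3nccn3C)cc2)c1` gives 43 nM in an assay on CHO cells for agonist activity at Free fatty acid receptor 1 (Homo sapiens), read by luminescence, with a stated time of 20 s, in the presence of a further agent that is not named here (on this read-out higher numbers stand for an effect only at larger amounts of compound and lower numbers for an effect already at smaller amounts), the lowest of the three numbers measured so far. Compound 2 `Cc1cc(Cl)ccc1-c1cc(COc2ccc([C@H](CC(=O)O)c3nccn3C)cc2)ccc1C` gives 97 nM, and compound 1 `COc1ccc(-c2cccc(COc3ccc([C@H](CC(=O)O)c4nccn4C)cc3)c2)cc1` gives 440 nM; compound 3 thus stands beyond the scatter from both, and the single shown step, a 10-fold lower number from compound 1 to compound 3 (1.01 log units; beyond the scatter), is large, exchanging a 2-methylphenyl for a 4-methoxyphenyl on an aromatic carbon.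

Compound 4 `COc1ccccc1-c1cccc(COc2ccc([C@H](CC(=O)O)c3nccn3C)cc2)c1` differs from compound 3 in one place: methoxy in place of methyl on an aromatic carbon. A methoxy replaces a methyl on an aromatic carbon of a six-membered aromatic ring of carbon only, ortho to a large group; one bond further out, the change reads 2-methylphenyl to 2-methoxyphenyl. No shown step isolates this exchange. The step from compound 1 to compound 3 involves a methoxy, but it also moves the group to a different position on the ring, so it cannot be read as a guide for methyl against methoxy at the same place. With the group kept ortho to the large group, the change is small in size and adds one hydrogen-bond acceptor, so a modest shift, if any, is expected.

Compound 4 is therefore estimated at 70 nM, within 25 nM to 200 nM in this assay, with the step of a 1.6-fold higher number from compound 3 to compound 4 (0.21 log units; within the scatter) expected to be within or close to the scatter.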

Compound 4, half-maximal effective concentration: 410 nM
For compound 4 the middle estimate is 5.9-fold (0.77 log units) below the measured one, and the stated range ends below it.
By their numbers in this assay, from the lowest: compound 3; then compound 2; then compounds 4 and 1 (each within the scatter of the next).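

In this assay, the exchange of methyl for methoxy on an aromatic carbon ortho to a large group proves to be a step of its own, a 9.5-fold higher number from compound 3 to compound 4 (0.98 log units; beyond the scatter), so this place does not treat the two groups alike, even though the change adds only a little in size. The second new step, a 1.1-fold lower number from compound 1 to compound 4 (0.03 log units; within the scatter), stays within the scatter, so with methoxy kept on the ring, 2-methoxyphenyl and 4-methoxyphenyl cannot be told apart on this read-out. Read together, the two steps take apart the earlier mixed change, a 10-fold lower number from compound 1 to compound 3 (1.01 log units; beyond the scatter): among these compounds its size goes with methyl against methoxy, and the shift of the methoxy from one ring place to the other adds nothing beyond the scatter. Nothing given here accounts for this difference between methyl and methoxy.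

As far as these compounds go, whether an ethyl, a chlorine, a hydroxyl or an amine in the same place would read like the methyl or like the methoxy remains open. So does whether the exchange of methyl for methoxy carries the same weight on the more substituted biaryl of compound 2, where a chlorine and a second methyl are also present.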